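The compounds below may be only part of what the source reports. "The series", "measured", "known", "first", "only" and "open" are said of these compounds alone.

Working notes on the series. Three members share a core and have been run in an assay on SH-SY5Y cells for inhibition of Voltage-dependent N-type calcium channel subunit alpha-1B (Homo sapiens), read by FLIPR and calcium flux, with stated times of 600 s and 300 s, in the presence of a further agent that is not named here; a lower number here means a stronger inhibitor, a higher number a weaker inhibitor. Compound 1 `NCCCOc1ccc(CNc2nc3ccc(Oc4ccc(C(F)(F)F)cc4)cc3s2)cc1` gives 59000 nM. Compound 2 `N=C(N)NCCCOc1ccc(CNc2nc3ccc(Oc4cccc(C(F)(F)F)c4)cc3s2)cc1` gives 130000 nM. Compound 3 `CN(Cc1ccc(OCCCN)cc1)c1nc2ccc(Oc3cccc(C(F)(F)F)c3)cc2s1` gives 77000 nM. Compound 3 stands second highest of the three numbers; its nearest neighbour is compound 1, and compound 2 lies furthest from it, but both of those gaps fall within the usual scatter, so the three cannot be ordered against one another on this evidence.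

Compound 4 `NCCCOc1ccc(CNc2nc3ccc(Oc4cccc(C(F)(F)F)c4)cc3s2)cc1` has not yet been measured. Relative to compound 3 the change is hydrogen in place of methyl on a nitrogen on an aromatic ring whose other neighbours are an aromatic carbon and a saturated chain carbon. Within the data shown here, no step between measured compounds covers this change. Given that every measured number in this assay sits in a narrow band, the step from compound 3 to compound 4 is expected to be small, a 1.1-fold lower number from compound 3 to compound 4 (0.04 log units; within the scatter), with no clear direction beyond the scatter. Compound 4 is therefore estimated at 70000 nM, in a range from 30000 nM to 160000 nM, in this assay.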

Compound 4, half-maximal inhibitory concentration: 144000 nM
Compound 4: middle estimate off by 2.1-fold (0.31 log units), on the low side; the measured number falls inside the stated range.
By their numbers in this assay, from the lowest: compounds 1, 3, 2 and 4 (each within the scatter of the next, the first and the last beyond it).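

In this assay, hydrogen in place of methyl on a nitrogen on an aromatic ring stays within the scatter, a 1.9-fold higher number from compound 3 to compound 4 (0.27 log units; within the scatter), and so does hydrogen in place of the group of 3 heavy atoms on an amine nitrogen, a 1.1-fold higher number from compound 2 to compound 4 (0.04 log units; within the scatter), so neither position yet shows a readable effect. Among these compounds, the one step beyond the scatter is modest and lies elsewhere: 3-(trifluoromethyl)phenyl in place of 4-(trifluoromethyl)phenyl on an oxygen on an aromatic ring gives a 2.4-fold higher number from compound 1 to compound 4 (0.39 log units; beyond the scatter). No measurement offered here bears on the origin of these numbers.

Still open, on these data alone, is whether an ethyl group on the nitrogen on an aromatic ring would give a step beyond the scatter. Also open, as far as these compounds go, is whether a chlorine in place of trifluoromethyl would do so.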